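Pyrazinyl in place of tolyl on a piperazine thiocarbamate

The compounds below may be only part of what the source reports. "The series", "measured", "known", "first", "only" and "open" are said of these compounds alone.

Of the compounds shown here, two that share a core have been tested in a functional assay on A-375 cells (Homo sapiens) for antiproliferative activity, read by CCK-8 assay, with a stated time of 72 h, tested at 2 uM; on this read-out higher numbers stand for a stronger effect at the one concentration tested and lower numbers for a weaker effect. Compound 1 `Nc1ccccc1NC(=O)c1ccc(CSC(=S)N2CCN(c3ccc(F)cc3)CC2)cc1` gives 20.9% in this assay, and compound 2 `Cc1ccc(N2CCN(C(=S)SCc3ccc(C(=O)Nc4ccccc4N)cc3)CC2)cc1` gives 25.8%. Among the measured compounds shown here, the only step between them, a number 4.9 percentage points higher from compound 1 to compound 2 (within the scatter), is small, so the two numbers are alike within the scatter, and compound 2 stands at one of two nearly equal values rather than apart from compound 1.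

Compound 3 `Nc1ccccc1NC(=O)c1ccc(CSC(=S)N2CCN(c3cnccn3)CC2)cc1` differs from compound 2 in one place: pyrazin-2-yl in place of 4-methylphenyl on an amine nitrogen in a ring. For the measured compounds named here, the one measured step, from compound 1 to compound 2, concerns a substituent on the same aromatic ring that is now exchanged, and it was within the scatter. Going by the values given here, no measured step concerns an exchange of the whole ring, so the expectation rests on this single small step alone, and the step in this assay from compound 2 to compound 3 is expected to be none beyond the scatter; the expected step is a number 2.8 percentage points lower from compound 2 to compound 3 (within the scatter). Compound 3 is therefore estimated to give 23%, with a range from 8% to 40%.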

Compound 3, a percentage reported as inhibition, at one concentration (the size of the read-out at that concentration, not a potency): 29.1%
Beside the measured number, compound 3's estimate is 6.1 percentage points below it; the measured number falls inside the stated range.
By their numbers in this assay, from the lowest: compounds 1, 2 and 3 (each within the scatter of the next).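

Until now only a substituent on the aromatic ring at this place had been exchanged, whereas here the whole ring changes, from one of carbon only to one with 2 hetero atoms. In this assay, this exchange gives a number 3.3 percentage points higher from compound 2 to compound 3 (within the scatter), and the exchange for 4-fluorophenyl gives a number 8.2 percentage points higher from compound 1 to compound 3 (within the scatter), so both steps stay within the scatter. At this one concentration, then, pyrazin-2-yl, with its 2 hydrogen-bond acceptors, gives a number alike to those of the two carbon-only rings on the amine nitrogen, and nothing available explains why the three numbers lie so close.

As far as these compounds go, all three compounds carry a six-membered aromatic ring at this place, so it remains open whether a simple methyl, a longer chain or a ring bearing a carboxylic acid would shift the number beyond the scatter. Since each number comes from a single concentration and all three are alike, they also leave open whether the compounds would differ in potency across a range of concentrations.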